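A few compounds are considered here, and "the series" means these few. Any claim that something is new, unique, unknown or untested is made for them only; others in the source may bear on it.

Going by the values given here, in a functional assay on PANC-1 cells (Homo sapiens) for inhibition, read by MTT assay, with a stated time of 24 h, tested at 10 uM (on this read-out higher numbers stand for more inhibition at the one concentration tested (going by the name of the read-out) and lower numbers for less inhibition), compound 3 `COc1ccc(NC(=O)Oc2cc(=O)n(CCCO)c3c2CC(CC=C(C)C)C(C)(C)C3)cc1` gives 3.7%, the smallest of the three numbers so far, though its nearest neighbour sits within the scatter of it. That neighbour is compound 1 `CC(C)=CCC/C(C)=C/COc1cc(=O)n(CCCO)c2c1CC(CC=C(C)C)C(C)(C)C2`, which gives 10.6% in this assay; the one-place change a number 6.9 percentage points lower from compound 1 to compound 3 (within the scatter) lies within the scatter. Compound 2 `COc1ccc(C(=O)NCCCOc2cc(=O)n(CCCO)c3c2CC(CC=C(C)C)C(C)(C)C3)cc1` stands furthest away with 55.5%, beyond the scatter from compound 3.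

Compound 4 `CC(C)=CCC1Cc2c(OC(=O)Nc3ccc(F)cc3F)cc(=O)n(CCCO)c2CC1(C)C` has not yet been measured. It differs from compound 3 in one place only: 2,4-difluorophenyl in place of 4-methoxyphenyl on an amide-type nitrogen. Among the compounds with values here, no measured step touches that position. Within the data shown here, the only one-place step known so far, from compound 1 to compound 3, concerns the group on the oxygen of the aromatic ring and was within the scatter, so it says nothing about a swap of one aryl for another on the amide-type nitrogen. The gap between compound 2 and compound 3 involves several changes at once and gives no guidance either. Among the measured compounds shown here, with no precedent for this kind of change, a step of a number 6.3 percentage points higher from compound 3 to compound 4 (within the scatter) is expected, that is none beyond the scatter. Compound 4 is therefore estimated at 10% in this assay, with a range from 0% to 35%.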

Compound 4, a percentage reported as inhibition, at one concentration (the size of the read-out at that concentration, not a potency): 69.7%
Estimate against measurement, compound 4: 59.7 percentage points below; measured number above the stated range.
By their numbers in this assay, from the lowest: compounds 3 and 1 (each within the scatter of the next); then compound 2; then compound 4.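

In this assay, going by these compounds alone, the swap of 4-methoxyphenyl for 2,4-difluorophenyl on the amide-type nitrogen gives a number 66 percentage points higher from compound 3 to compound 4 (beyond the scatter), showing that the aryl group at this position can decide the read-out, which no earlier compound could show. The carbamoyl link on the oxygen therefore does not by itself hold the number low: with (4-methoxyphenyl)carbamoyl in place of 3,7-dimethylocta-2,6-dien-1-yl the change is a number 6.9 percentage points lower from compound 1 to compound 3 (within the scatter), whereas with (2,4-difluorophenyl)carbamoyl in that place it is a number 59.1 percentage points higher from compound 1 to compound 4 (beyond the scatter). Nothing available here accounts for the size of this swap.

The compounds shown leave open whether both fluorines are needed, and how a plain phenyl, a 4-fluorophenyl or a 2,4-dichlorophenyl group would compare on the same nitrogen. They also leave open whether the order seen at one concentration would hold across a full concentration series, so the size of the read-out for compound 4 cannot yet be turned into a potency.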